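Chloro for Methyl on the Pyridyloxy Arm

This account rests on a few compounds, and the source may have more. Where it says the series, first, only, none or still open, it means among the compounds named here.

Measured compounds:
Compound 1 `CC(CCNC(=O)c1c(Cl)cncc1Cl)N1CCC(C(Oc2ccncc2)c2ccc(Br)cc2)CC1`: 31200 nM
Compound 2 `CC(CCNC(=O)c1c(Cl)cncc1Cl)N1CCC(C(Oc2ccccn2)c2ccc(Br)cc2)CC1`: 33700 nM
Compound 3 `Cc1ccnc(OC(c2ccc(C(F)(F)F)cc2)C2CCN(C(C)CCNC(=O)c3c(Cl)cncc3Cl)CC2)c1`: 33600 nM

In an ADME assay on PBMC cells (Homo sapiens) for cytotoxicity (on this read-out lower numbers stand for higher toxicity in this test and higher numbers for lower toxicity in this test), the three measured compounds sit close together. Compound 3 holds the second highest of the three numbers; its nearest neighbour is compound 2 and its furthest is compound 1, and both gaps lie within the scatter. Among the measured compounds shown here, the only measured step that changes one place is a 1.1-fold higher number from compound 1 to compound 2 (0.03 log units; within the scatter), which swaps the ring attached through the oxygen and leaves the number unchanged within the scatter.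

Compound 4 `CC(CCNC(=O)c1c(Cl)cncc1Cl)N1CCC(C(Oc2cc(Cl)ccn2)c2ccc(C(F)(F)F)cc2)CC1` is obtained from compound 3 by the change (chloro in place of methyl on an aromatic carbon), that is 4-methylpyridin-2-yl to 4-chloropyridin-2-yl. For the measured compounds named here, no measured step involves this exchange, so nothing among the measured compounds speaks for a shift in this assay in either direction. Given that all three measured numbers lie within the scatter of one another, compound 4 is expected to give a number close to compound 3, with a step of a 1.0-fold lower number from compound 3 to compound 4 (0.01 log units; within the scatter) that stays within the scatter. The estimate for compound 4 in this assay is 33000 nM, within a range from 16000 nM to 66000 nM.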

Compound 4, half-maximal cytotoxic concentration: 4260 nM
The estimate for compound 4 lay 7.7-fold (0.89 log units) above the measured number, outside the stated range (below it).
By their numbers in this assay, from the lowest: compound 4; then compounds 1, 3 and 2 (each within the scatter of the next).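

In this assay, the place opposite the ring nitrogen proves sensitive to the exchange of 4-methylpyridin-2-yl for 4-chloropyridin-2-yl, with a 7.9-fold lower number from compound 3 to compound 4 (0.90 log units; beyond the scatter), whereas the earlier change of the ring attached through the oxygen, a 1.1-fold higher number from compound 1 to compound 2 (0.03 log units; within the scatter), left the number unchanged within the scatter. The exchange replaces one heavy atom with one heavy atom and leaves the counts of hydrogen-bond donors, hydrogen-bond acceptors and net charge the same, so a small change on this ring is enough to produce a step beyond the scatter. Nothing available bears on why the number moved.

As far as these compounds go, whether other groups at this place, such as fluoro, methoxy or an amine, would also lower the number remains open. From the compounds shown here alone, it is also open whether the same exchange would give a similar step with bromo in place of trifluoromethyl.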